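A few compounds are considered here, and "the series" means these few. Any claim that something is new, unique, unknown or untested is made for them only; others in the source may bear on it.

Compound 1 `CS(=O)(=O)N1C(=O)COC12C=CC(=O)C=C2` is the plainest member of this small series, and it was tested in a functional assay on HepG2 cells (Homo sapiens) for inhibition, read by sulforhodamine B assay, with a stated time of 74 h; on this read-out lower numbers stand for stronger inhibition and higher numbers for weaker inhibition. In this assay compound 1 gives > 10000 nM, which is a limit of the assay and not a number. Compound 1 therefore stands at the limit of > 10000 nM in this assay, at which 1 of the 2 values shown sits, and no exact potency can be read for it.

Compound 2 `COc1ccc(S(=O)(=O)N2C(=O)COC23C=CC(=O)C=C3)cc1` keeps the shared core but carries a ring-bearing group on the sulfonyl sulfur in place of methyl, and in this assay compound 2 gives a true number, 1620 nM.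

Compound 3 `O=C1C=CC2(C=C1)OCC(=O)N2S(=O)(=O)c1cccs1` has not yet been measured. It has thiophen-2-yl in place of methyl on a sulfonyl sulfur, and the change is thiophen-2-yl in place of methyl on a sulfonyl sulfur.

Among the measured compounds shown here, compound 2, at 1620 nM, is the only guide here, since it also has a ring on the sulfonyl sulfur, so a move towards stronger inhibition, beyond the usual scatter, is expected. The expected size of this move is an at least 4.0-fold lower number from compound 1 to compound 3 (0.60 log units; beyond the scatter), an estimate resting on very little data. Compound 3 is expected at about 2500 nM, with an estimated range from 700 nM to 9000 nM.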

Compound 3, half-maximal inhibitory concentration: > 10000 nM
Compound 3 was reported as a limit; the forecaster's own chance of this, stated with the estimate: 15%; middle value at least 4.0-fold (0.60 log units) away from the limit.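

Compound 3, like compound 1, is reported only as a limit of the assay and not as a number, so no step can be read between compound 1 and compound 3: the limit of > 10000 nM in this assay, at which 2 of the 3 values shown sit.

As far as these compounds go, what stays open is how strongly compound 1 and compound 3 inhibit in this assay, and whether thiophen-2-yl in place of methyl on a sulfonyl sulfur changes that at all.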